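Compound 2 and the Step from Methoxy to Hydroxy

The source may hold more compounds than are shown below. What is called first, only, known or untested is meant among the compounds shown, and "the series" means these compounds.

Within the data shown here, in a functional assay on MCF7 cells (Homo sapiens) for inhibition, read by MTT assay (a higher number here means a weaker inhibitor of growth, a lower number a stronger inhibitor of growth), compound 1 `COc1cc2oc(-c3cccc(NC(=O)c4ccc(Cl)cc4)c3)cc(=O)c2c(OC)c1OC` gives 8780 nM and compound 2 `COc1ccc(C(=O)Nc2cccc(-c3cc(=O)c4c(OC)c(OC)c(OC)cc4o3)c2)cc1` gives 6870 nM with the two numbers lying within the scatter of each other, so compound 2 stands level with the only other measured compound. The change to compound 3 `COc1ccc(C(=O)Nc2cccc(-c3cc(=O)c4c(O)c(OC)c(OC)cc4o3)c2)cc1` is methoxy to hydroxy, counted as hydrogen in place of methyl on an oxygen on an aromatic ring with hydrogen in place of methyl on an oxygen on an aromatic ring. Among the measured compounds shown here, the one measured step, a 1.3-fold lower number from compound 1 to compound 2 (0.11 log units; within the scatter) for methoxy in place of chloro on an aromatic carbon, lies within the scatter but concerns a different change in a different place, so it bears only loosely here. For the measured compounds named here, no measured pair shows the loss of this methyl, and no shift beyond the scatter is therefore expected in this assay for now. The estimated move is a 1.4-fold lower number from compound 2 to compound 3 (0.14 log units; within the scatter) and it stays within the scatter. Compound 3 is expected at 5000 nM within an estimated range of 1800 nM to 14000 nM once measured.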

Compound 3, concentration for 50% growth inhibition: 2050 nM
Estimate against measurement, compound 3: 2.4-fold (0.39 log units) above; the measured number falls inside the stated range.
By their numbers in this assay, from the lowest: compound 3; then compounds 2 and 1 (each within the scatter of the next).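

In this assay, hydrogen in place of methyl on an oxygen on an aromatic ring gives a 3.4-fold lower number from compound 2 to compound 3 (0.53 log units; beyond the scatter), and this is the only step shown that passes beyond the scatter. Among these compounds, the one other step, a 1.3-fold lower number from compound 1 to compound 2 (0.11 log units; within the scatter), concerned methoxy in place of chloro on an aromatic carbon and showed no clear shift, so this oxygen is the one place where a change is seen to move the number in this assay. Nothing at hand accounts for the size or the direction of this step.

The compounds shown leave open whether the same loss of methyl would act alike with the chloro of compound 1 in place of the methoxy, or at the remaining methoxy groups of the core. They also leave open what an amine or a longer chain such as ethoxy would do in place of this hydroxy.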